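A few compounds are considered here, and "the series" means these few. Any claim that something is new, unique, unknown or untested is made for them only; others in the source may bear on it.

Measured so far:
Compound 1, `CC1=C(C(=O)OC(C)C)C(c2cccs2)NC(=O)N1C`: in an assay on CHO cells for displacement of a labelled ligand from adenosine receptor A1 (Homo sapiens), with a stated time of 60 min, tested at 10 uM (on this read-out higher numbers stand for more inhibition at the one concentration tested (going by the name of the read-out) and lower numbers for less inhibition), compound 1 gives 22%.
Compound 2, `CCOC(=O)C1=C(C)N(C)C(=O)NC1c1ccoc1`: in this assay compound 2 gives 17%.

Compound 2 stands at the bottom of the two readings taken so far, yet the reading of compound 1 lies within the scatter of it, so neither compound is ranked above the other. Compound 1 and compound 2 also differ in more than one place, so the pair is read for nothing beyond its two values: both sit at the low end of the scale in this assay.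

The next member, compound 3, `CC1=C(C(=O)OC(C)C)C(c2ccoc2)NC(=O)N1C`, is reached from compound 2 by a single change: methyl in place of hydrogen on a saturated chain carbon bound to an oxygen next to a carbonyl group and a saturated chain carbon. The isopropoxycarbonyl group that enters is already present in compound 1, whose reading falls within the scatter of compound 2. Among the compounds with values here, no measured step of this kind exists in the set, so the expected step is small and without clear direction, a number 3 percentage points higher from compound 2 to compound 3 (within the scatter), within the scatter. Compound 3 is accordingly estimated at 20%, with a range from 8% to 32%.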

Compound 3, a percentage reported as inhibition, at one concentration (the size of the read-out at that concentration, not a potency): 23%
Compound 3: middle estimate off by 3 percentage points, on the low side; measured number inside the range.
By their numbers in this assay, from the lowest: compounds 2, 1 and 3 (each within the scatter of the next).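

The change from ethoxycarbonyl to isopropoxycarbonyl now has a measured step of its own on the core carrying furan-3-yl: in this assay it gives a number 6 percentage points higher from compound 2 to compound 3 (within the scatter), so methyl in place of hydrogen at this saturated chain carbon does not separate the two compounds. With the isopropoxycarbonyl group held constant, furan-3-yl in place of thiophen-2-yl on a saturated ring carbon gives a number 1 percentage points higher from compound 1 to compound 3 (within the scatter), so this exchange of ring groups does not separate its pair either, and all three compounds remain at the low end of the scale. No measurement at hand bears on the reason for these readings.

From the compounds shown here alone, it remains open whether a butoxycarbonyl group, with its longer chain, or a carboxylic acid in place of the isopropoxycarbonyl group would move the reading beyond the scatter. Going by these compounds, it is equally open whether a phenyl ring or an aminophenyl group in place of furan-3-yl on the saturated ring carbon would do so.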